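A Smaller Triazole Substituent and Cellular Toxicity

The source may hold more compounds than are shown below. What is called first, only, known or untested is meant among the compounds shown, and "the series" means these compounds.

The three measured compounds were examined in an ADME assay on MT4 cells (Homo sapiens) for cytotoxicity, read by MTT assay, with a stated time of 5 days; on this read-out higher numbers stand for lower toxicity in this test and lower numbers for higher toxicity in this test:

Compound 1 `Cc1cc(C)c(Oc2cc(Nc3ccc(C#N)cc3)ncc2C(=O)NCc2cn(Cc3ccccc3F)nn2)c(C)c1`: > 222000 nM
Compound 2 `Cc1cc(C)c(Oc2cc(Nc3ccc(C#N)cc3)ncc2C(=O)NCc2cn(Cc3ccccc3C#N)nn2)c(C)c1`: > 219000 nM
Compound 3 `Cc1cc(C)c(Oc2cc(Nc3ccc(C#N)cc3)ncc2C(=O)NCc2cn(Cc3ccccc3Cl)nn2)c(C)c1`: >= 188000 nM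

Each of these three values is a limit of the assay rather than a number. Among the compounds with values here, compound 3 thus stands at a limit, and the two further values are limits as well, so no compound can be placed above or below another. The single-point changes among them, cyano in place of fluoro giving a step that the two limits leave unreadable from compound 1 to compound 2, chloro in place of fluoro giving a step that the two limits leave unreadable from compound 1 to compound 3, and chloro in place of cyano giving a step that the two limits leave unreadable from compound 2 to compound 3, are all unreadable because of the limit of > 219000 nM in this assay, at which 1 of the 3 values shown sits, the limit of > 222000 nM in this assay, at which 1 of the 3 values shown sits, and (the limit of >= 188000 nM in this assay, at which 1 of the 3 values shown sits).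

Compound 4 `Cc1cc(C)c(Oc2cc(Nc3ccc(C#N)cc3)ncc2C(=O)NCc2cn(CCC#N)nn2)c(C)c1` differs from compound 3 by cyanomethyl in place of 2-chlorophenyl on a saturated chain carbon bound to an aromatic nitrogen. Within the data shown here, none of the measured steps touches this kind of change, and none of them is readable in size anyway, so they give no direction. The shared core is unchanged, and every measured compound sits at a limit; the expectation is no step beyond the scatter. Compound 4 is therefore estimated to give 200000 nM, with a range from 100000 nM to 300000 nM. The expected step is a step that the limit leaves unreadable from compound 3 to compound 4, which is within the scatter.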

Compound 4, half-maximal cytotoxic concentration: 40200 nM
Compound 4: the middle estimate sits 5.0-fold (0.70 log units) above what was measured; measured number below the stated range.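

In this assay, cyanomethyl in place of 2-chlorophenyl on a saturated chain carbon bound to an aromatic nitrogen gives an at least 4.6-fold lower number from compound 3 to compound 4 (0.66 log units; beyond the scatter), and the same place gives an at least 5.4-fold lower number from compound 2 to compound 4 (0.73 log units; beyond the scatter) and also an at least 5.5-fold lower number from compound 1 to compound 4 (0.74 log units; beyond the scatter) when the group that leaves is 2-cyanophenyl or 2-fluorophenyl. Within the data shown here, compound 4 is the only compound here whose value is a number rather than a limit, and it shows that a change at this place can shift the read-out towards higher toxicity in this test, which the three compounds with aromatic groups, all sitting at limits, could not show. Each of the three steps is a minimum size because its other end is a limit: the limit of > 219000 nM in this assay, at which 1 of the 4 values shown sits, and the limit of > 222000 nM in this assay, at which 1 of the 4 values shown sits, and the limit of >= 188000 nM in this assay, at which 1 of the 4 values shown sits.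

The compounds shown leave open whether the lower number goes with the loss of the aromatic ring or with the entry of the nitrile. They also leave open where an unsubstituted benzyl or a longer chain ending in a nitrile would fall at this place.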